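Solubility notes on a shared aminopyridine-linked series

The source may hold more compounds than are shown below. What is called first, only, known or untested is meant among the compounds shown, and "the series" means these compounds.

Measured so far:
compound 1 `COc1ccc(-c2cc(-c3ccc(NS(C)(=O)=O)cc3)cnc2N)cn1`: 25 ug/mL
compound 2 `COc1ccc(-c2cnc(N)c(-c3ccc(OC)nc3)c2)cn1`: 25 ug/mL
compound 3 `COc1ccc(-c2cc(-c3ccc4nccn4c3)cnc2N)cn1`: 12.5 ug/mL

In a physicochemical assay for solubility, read by nephelometry, in phosphate buffer, measured as kinetic solubility, at pH 6.5 (on this read-out lower numbers stand for lower solubility and higher numbers for higher solubility), compound 1 gives 25 ug/mL, level with compound 2 at the digits shown and together the highest of the three numbers; compound 3 gives 12.5 ug/mL, a difference that stays within the scatter. Within the data shown here, no pair that differs in one place has been measured, so no step size is known from data.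

Compound 4 `COc1ccc(-c2cc(-c3ccc(C(N)=O)cc3)cnc2N)cn1` is not yet measured. It differs from compound 1 by carbamoyl in place of methanesulfonamido on an aromatic carbon. Among the measured compounds shown here, with no matching step available, the expectation for compound 4 is no change beyond the scatter, no change at the digits printed from compound 1 to compound 4 (within the scatter), and its estimated result in this assay is 25 ug/mL, within 8 ug/mL to 70 ug/mL.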

Compound 4, solubility: 12.5 ug/mL
For compound 4 the middle estimate is 2.0-fold (0.30 log units) above the measured one, and the stated range covers the measured number.
By their numbers in this assay, from the lowest: compounds 3, 4, 1 and 2 (each within the scatter of the next).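

In this assay, among these compounds, the first matched pair at this position, on an aromatic carbon para to a large group, reads a 2.0-fold lower number from compound 1 to compound 4 (0.30 log units; within the scatter) and so gives the change of carbamoyl in place of methanesulfonamido no size beyond the scatter. This single pair shows that these two groups are not told apart by this read-out on the core of compound 1. No measurement at hand bears on the origin of this step.

On these data alone, whether an amine or a carboxylic acid at this position would give a step beyond the scatter remains open. Also open, as far as these compounds go, is whether the same change would read alike on another core.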